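Swapping the amide substituent on a quinazoline-type scaffold

A few compounds are considered here, and "the series" means these few. Any claim that something is new, unique, unknown or untested is made for them only; others in the source may bear on it.

Two compounds share a common core. Compound 1 `CCCNc1nc(NCc2ccc(C(=O)Nc3ccc(Cl)nc3)cc2)c2cc(C)ccc2n1` is measured in a functional assay on HCT-116 cells (Homo sapiens) for inhibition, read by luminescence and resazurin assay, with a stated time of 3 days (a lower number here means a stronger inhibitor, a higher number a weaker inhibitor), and gives 1500 nM. Compound 2 `Cc1ccc2nc(N(C)C)nc(NCc3ccc(C(=O)N[C@H]4C[C@@H]4c4ccccc4)cc3)c2c1` has the lower of the two numbers, and in this assay compound 2 gives 1300 nM, which sits within the scatter of compound 1. Compound 3 `Cc1ccc2nc(N(C)C)nc(NCc3ccc(C(=O)Nc4ccc(Cl)nc4)cc3)c2c1` is not yet measured; it carries 6-chloropyridin-3-yl in place of 2-phenylcyclopropyl on an amide-type nitrogen, the same amide substituent that compound 1 bears. For the measured compounds named here, no measured pair shows this change directly. Since compound 1 gives 1500 nM with that group, the step of a 1.1-fold higher number from compound 2 to compound 3 (0.03 log units; within the scatter) is expected to stay within the scatter. Compound 3 is estimated at 1400 nM, with a range from 500 nM to 4000 nM.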

Compound 3, half-maximal inhibitory concentration: 1300 nM
For compound 3 the middle estimate is 1.1-fold (0.03 log units) above the measured one; measured number inside the range.
By their numbers in this assay, from the lowest: compounds 2, 3 and 1 (each within the scatter of the next).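

In this assay the change to 6-chloropyridin-3-yl in place of 2-phenylcyclopropyl on the amide-type nitrogen gives no change at the digits printed from compound 2 to compound 3 (within the scatter) and so shows that this position holds either group with no step beyond the scatter. On the aromatic carbon, dimethylamino in place of propylamino gives a 1.2-fold lower number from compound 1 to compound 3 (0.06 log units; within the scatter) and is likewise within the scatter. Nothing available explains why either change leaves the number in place.

Still open, on these data alone, is whether a carboxylic acid or a primary amine on the amide-type nitrogen, or a longer chain such as hexylamino on the aromatic carbon, gives a step beyond the scatter.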